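A few compounds are considered here, and "the series" means these few. Any claim that something is new, unique, unknown or untested is made for them only; others in the source may bear on it.

Measured in a functional assay on SMMC-7721 cells (Homo sapiens) for cytotoxicity, read by MTT assay, with a stated time of 24 h; a lower number here means a stronger inhibitor, a higher number a weaker inhibitor:
- Compound 1 `O=C1/C(=C/c2ccncc2)CNC/C1=C\c1ccccc1F`: 18400 nM
- Compound 2 `O=C1/C(=C/c2ccncc2)CNC/C1=C\c1ccccc1C(F)(F)F`: 4500 nM

Compound 2, at 4500 nM, has the lower of the two numbers, so it is the stronger inhibitor of this pair. The next compound, compound 3 `O=C1/C(=C/c2ccncc2)CN(S(=O)(=O)c2ccc([N+](=O)[O-])cc2)C/C1=C\c1ccccc1C(F)(F)F`, has not been measured. It differs from compound 2 in one place: (4-nitrophenyl)sulfonyl in place of hydrogen on an amine nitrogen in a ring. In words, (4-nitrophenyl)sulfonyl stands in place of hydrogen on an amine nitrogen in a ring.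

Among the compounds with values here, only one measured step exists: a 4.1-fold lower number from compound 1 to compound 2 (0.61 log units; beyond the scatter), with trifluoromethyl in place of fluoro on an aromatic carbon. That step is modest but beyond the scatter. It lies elsewhere on the molecule, so it bears on the new change only loosely, as a rough guide to how far one substitution can move the number. Neither measured compound carries a group on that amine nitrogen, so the direction is a tentative call and the range must stay wide.

The expected change is similarly modest, and the estimate amounts to a 2.3-fold lower number from compound 2 to compound 3 (0.35 log units; beyond the scatter). In this assay, compound 3 is estimated at 2000 nM, with an expected range of 500 nM to 9000 nM.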

Compound 3, half-maximal inhibitory concentration: > 20000 nM
Compound 3: no number, only a limit (the forecaster's own chance of this, stated with the estimate: 5%); at least 10-fold (1.00 log units) between middle value and limit.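

In this assay compound 3 gives no number, only a limit: the limit of > 20000 nM in this assay, at which 1 of the 3 values shown sits.

Even so, the direction can be read, since (4-nitrophenyl)sulfonyl in place of hydrogen on the ring amine nitrogen gives an at least 4.4-fold higher number from compound 2 to compound 3 (0.64 log units; beyond the scatter), which makes compound 3 the weaker inhibitor of the two. Within the data shown here, compound 1 and compound 2 both keep hydrogen on that nitrogen and differ only in a group on an aromatic carbon, so they said nothing about this position; the new result is the first sign that the number responds to a change there, and that this group moves it towards weaker inhibition.

One group on one nitrogen cannot show whether the loss belongs to the sulfonyl link, to the 4-nitrophenyl ring or to any substituent at all in place of that hydrogen, and the limit leaves the full size of the step unknown. A methyl group, an acetyl group or a plain benzenesulfonyl group on the same nitrogen would help to separate these possibilities.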